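Chloro on the benzimidazole of a weak cytotoxic quinolone

The source may hold more compounds than are shown below. What is called first, only, known or untested is meant among the compounds shown, and "the series" means these compounds.

Measured so far:
compound 1 `CCn1cc(-c2nc3ccccc3[nH]2)c(=O)c2cc(F)c(N3CCNCC3)cc21`: > 10000 nM
compound 2 `CCn1cc(-c2nc3ccccc3[nH]2)c(=O)c2cc(F)c(N3CCNCC3)nc21`: 6800 nM

Of the compounds shown here, two have been tested in a functional assay on HepG2 cells (Homo sapiens) for cytotoxicity, read by sulforhodamine B assay, with a stated time of 48 h; on this read-out lower numbers stand for stronger inhibition of growth and higher numbers for weaker inhibition of growth. For compound 1 the result is a limit of the assay rather than a number: > 10000 nM, which means (the limit of > 10000 nM in this assay, at which 1 of the 2 values shown sits). Compound 2, in this assay, gives 6800 nM. For the measured compounds named here, no step between these two is counted, so the pair says only what its two values show.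

Compound 3 `CCn1cc(-c2nc3ccc(Cl)cc3[nH]2)c(=O)c2cc(F)c(N3CCNCC3)cc21` has not yet been tested. It differs from compound 1 in one place: chloro in place of hydrogen on an aromatic carbon. Compound 1 sits at the limit, so its own value gives no scale for the change.

From the change 1H-benzimidazol-2-yl to 6-chloro-1H-benzimidazol-2-yl, compound 3 is expected to move by an at least 1.1-fold lower number from compound 1 to compound 3 (0.04 log units; that floor lies within the scatter), which is within the scatter. Compound 3 is expected to give about 9000 nM in this assay, in the range 2500 nM to 30000 nM.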

Compound 3, concentration for 50% growth inhibition: 1800 nM
Compound 3: middle estimate off by 5.0-fold (0.70 log units), on the high side, outside the stated range (below it).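

Chloro in place of hydrogen on an aromatic carbon of the benzimidazole, the change of 1H-benzimidazol-2-yl to 6-chloro-1H-benzimidazol-2-yl, gives in this assay an at least 5.5-fold lower number from compound 1 to compound 3 (0.74 log units; beyond the scatter). The two earlier compounds offered no counted step, so this is the only evidence shown that this position responds at all, and a single chlorine atom is enough for a change beyond the scatter. Compound 1 stands at a limit of the assay and not at a number, so the step gives only a floor for the size of the change: the limit of > 10000 nM in this assay, at which 1 of the 3 values shown sits.

Going by these compounds, whether a fluoro, a methoxy or a trifluoromethyl at this position would act like chloro stays open. So does whether chloro would bring a similar step on the core of compound 2, and the compounds shown do not tell why the number falls.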